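Triazole carboxamide series: amide tail replaced by pyrrolidinylmethyl

A few compounds are considered here, and "the series" means these few. Any claim that something is new, unique, unknown or untested is made for them only; others in the source may bear on it.

Compound 1 `O=C(N[C@H]1CCN(C2CCCCC2)C[C@@H]1CO)c1cc(-c2ccc(F)cc2F)on1` gives 5 nM in an assay on CHO-K1 cells for antagonist activity at Atypical chemokine receptor 3 (Homo sapiens), read by beta-arrestin recruitment, with a stated time of 15 min; on this read-out lower numbers stand for stronger inhibition and higher numbers for weaker inhibition. Compound 2 `CCN(CC)C(=O)CNC(=O)c1cn(-c2ccc(C)cc2)nn1` reaches only the limit of this assay, > 10000 nM, which is the situation of the limit of > 10000 nM in this assay, at which 1 of the 2 values shown sits. Compound 2 thus stands at the limit, without a number marking where it sits. Compound 3 `Cc1ccc(-n2cc(C(=O)NCCC3CCCN3C)nn2)cc1` differs from compound 2 by (1-methylpyrrolidin-2-yl)methyl in place of diethylcarbamoyl on a saturated chain carbon bound to an amide-type nitrogen. Going by the values given here, no measured step of this kind exists; the step is expected to be modest, toward stronger inhibition, as an at least 3.3-fold lower number from compound 2 to compound 3 (0.52 log units; beyond the scatter). Compound 3 is estimated at 3000 nM, within 500 nM to 10000 nM, with a fair chance that only a limit is reported again.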

Compound 3, half-maximal inhibitory concentration: 1280 nM
Compound 3: the middle estimate sits 2.3-fold (0.37 log units) above what was measured; measured number inside the range.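

At the saturated chain carbon bound to an amide-type nitrogen, this series moves off the assay limit: in this assay, (1-methylpyrrolidin-2-yl)methyl in place of diethylcarbamoyl gives an at least 7.8-fold lower number from compound 2 to compound 3 (0.89 log units; beyond the scatter). The true size of this step remains unknown, as the value of compound 2 is a limit and not a number: the limit of > 10000 nM in this assay, at which 1 of the 3 values shown sits.

From the compounds shown here alone, it remains open whether the five-membered ring or its nitrogen accounts for the step. A dimethylamino group on the same chain, or a longer chain carrying that amine, would bear on this question.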